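Working notes on an amide swap at a carbonyl carbon

The source may report more compounds than this note shows. Statements on the series, on what has been measured and on what is new or still open speak of the compounds shown alone.

Measured so far:
compound 1, `CN(C)C(=O)c1ccc(-c2cc(C3=CC(=O)C=CC3=O)no2)s1`, 7200 nM
compound 2, `COc1ccc(OC)c(-c2cc(-c3ccc(C(=O)N4CCCC4)s3)on2)c1`, > 30000 nM

In a functional assay on PC-3 cells (Homo sapiens) for cytotoxicity, read by XTT assay, with a stated time of 72 h (a lower number here means a stronger inhibitor, a higher number a weaker inhibitor), compound 1 gives 7200 nM. Compound 2 stands apart: in this assay it gives only a limit, > 30000 nM, which is the reporting limit itself (the limit of > 30000 nM in this assay, at which 1 of the 2 values shown sits), so no number is known for it. Compound 3, `COc1ccc(OC)c(-c2cc(-c3ccc(C(=O)NCC4CC4)s3)on2)c1`, differs from compound 2 in one place: (cyclopropylmethyl)amino in place of pyrrolidin-1-yl on a carbonyl carbon. Among the compounds with values here, no step between two measured compounds is available for comparison, and compound 1 shares too little with compound 2 for its value to guide this swap. With compound 2 sitting at the limit, the step from compound 2 to compound 3 is expected to be none beyond the scatter, a number no higher from compound 2 to compound 3 (the limit leaves the size open). Compound 3 is therefore estimated at 30000 nM, within 10000 nM to 100000 nM, and most likely again reported only as a limit.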

Compound 3, half-maximal inhibitory concentration: > 30000 nM
Compound 3 was reported as a limit (the forecaster's own chance of this, stated with the estimate: 70%); the middle value sits exactly at the limit.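

Compound 2 and compound 3 both stand only as limits in this assay, so no step between them can be read: the limit of > 30000 nM in this assay, at which 2 of the 3 values shown sit.

The compounds shown leave open whether (cyclopropylmethyl)amino in place of pyrrolidin-1-yl on a carbonyl carbon changes the potency at all.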